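Hydrogen for Methyl on an Aromatic Nitrogen

The compounds below may be only part of what the source reports. "The series", "measured", "known", "first", "only" and "open" are said of these compounds alone.

The account covers three measured compounds and one whose number is still to come. Compound 1 `Cn1c(/C=C/C(=O)c2ccccc2O)cc(Br)c1Br` gives 330 nM in a functional assay on WRL68 cells (Homo sapiens) for cytotoxicity, read by MTT assay, with stated times of 6 h and 48 h; a higher number here means a weaker inhibitor, a lower number a stronger inhibitor. Compound 2 `COc1ccc(C(=O)/C=C/c2cc(Br)c(Br)n2C)c(OC)c1` gives 640 nM in this assay, and its difference from compound 1 lies in more than one place, so the difference between the two cores is not broken down here. Compound 3 `O=C(/C=C/c1cc(Br)c(Br)[nH]1)c1ccccc1O` gives 1420 nM in this assay.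

Compound 3 is compound 1 with a single change, (hydrogen in place of methyl on an aromatic nitrogen), and the step of a 4.3-fold higher number from compound 1 to compound 3 (0.63 log units; beyond the scatter). Set against compound 1, the number of compound 2 lies within the usual scatter, whereas set against compound 3 it lies beyond it.

Compound 4 `COc1ccc(C(=O)/C=C/c2cc(Br)c(Br)[nH]2)c(OC)c1` carries the same change made on compound 2: hydrogen in place of methyl on an aromatic nitrogen. The surroundings of the place are the same word for word in both cases, so it is the same change, and it occurs twice among these compounds. Going by the values given here, the expectation for compound 2 to compound 4 in this assay rests on the measured pair alone, because the step of a 4.3-fold higher number from compound 1 to compound 3 (0.63 log units; beyond the scatter) is the only guide to how this change behaves on this core, and compound 2 is expected to move by a 4.3-fold higher number from compound 2 to compound 4 (0.63 log units; beyond the scatter). Compound 4 is therefore expected to give 2750 nM in this assay. Among the compounds with values here, the estimate for compound 4 is expected to span from 1200 nM to 6000 nM, wider than the single observed step alone would suggest, since one pair cannot fix how faithfully the change repeats.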

Compound 4, half-maximal inhibitory concentration: 9220 nM
Compound 4: the middle estimate sits 3.4-fold (0.53 log units) below what was measured, and the stated range ends below it.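

In this assay, hydrogen in place of methyl on an aromatic nitrogen again raises the number, and the new step is a 14-fold higher number from compound 2 to compound 4 (1.16 log units; beyond the scatter), so the direction of the change carries over from the core of compound 1 to the core of compound 2. The size of the change does not carry over, and the gap between the two steps is larger than repeated measurement would account for: the same change on two cores in this assay, a 4.3-fold higher number (0.63 log units; beyond the scatter) from compound 1 to compound 3 and a 14-fold higher number (1.16 log units; beyond the scatter) from compound 2 to compound 4, 3.3-fold (0.52 log units) apart, beyond the scatter of two such steps This does not show why the size differs, and two pairs on two cores give no rule for what the same change would do on a third core.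

The two cores differ in more than one place, and the compounds shown do not tell which of those differences goes with the larger step. Going by these compounds, they also carry only methyl or hydrogen on that aromatic nitrogen, so it remains open how a longer chain such as ethyl or propyl, or a chain ending in an amine or a carboxylic acid, would compare there on either core.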